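Dichlorophenyl to methoxyphenyl at the chain carbon

The source may report more compounds than this note shows. Statements on the series, on what has been measured and on what is new or still open speak of the compounds shown alone.

Compound 2 `Oc1c(C(Nc2ccccn2)c2c(Cl)cccc2Cl)ccc2cccnc12` stands highest of the two numbers in an assay for inhibition of protein disulfide-isomerase (Homo sapiens), with a stated time of 1 h (a higher number here means a weaker inhibitor, a lower number a stronger inhibitor), where compound 2 gives 1890 nM. Nearest is compound 1 `Oc1c(C(Nc2ccccn2)c2ccccc2Cl)ccc2cccnc12`, which in this assay gives 500 nM. Within the data shown here, the single measured step, a 3.8-fold higher number from compound 1 to compound 2 (0.58 log units; beyond the scatter), came with chloro in place of hydrogen on an aromatic carbon. Compound 3 `COc1cccc(C(Nc2ccccn2)c2ccc3cccnc3c2O)c1` carries 3-methoxyphenyl in place of 2,6-dichlorophenyl on a saturated chain carbon bound to an aromatic carbon and a nitrogen on an aromatic ring. Nothing measured covers the methoxy; only the chloro step bears, and here both chlorines leave. For compound 3 the estimate in this assay is 600 nM (range 200 nM to 2000 nM). The expected step is a 3.2-fold lower number from compound 2 to compound 3 (0.50 log units; beyond the scatter), because a 3.8-fold higher number from compound 1 to compound 2 (0.58 log units; beyond the scatter) accompanied chloro added.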

Compound 3, half-maximal inhibitory concentration: 2860 nM
Estimate against measurement, compound 3: 4.8-fold (0.68 log units) below; the whole stated range lies below it.
By their numbers in this assay, from the lowest: compound 1; then compounds 2 and 3 (each within the scatter of the next).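

At the saturated chain carbon, 3-methoxyphenyl and 2,6-dichlorophenyl cannot be told apart in this assay, with a 1.5-fold higher number from compound 2 to compound 3 (0.18 log units; within the scatter), so replacing that group did not recover the number of compound 1. Against 2-chlorophenyl, the same replacement gives a 5.7-fold higher number from compound 1 to compound 3 (0.76 log units; beyond the scatter), leaving the single chlorine group ahead of both others. No evidence on hand accounts for these numbers. Still open, from the compounds shown here alone, is how an unsubstituted phenyl would compare at this carbon, which would separate the loss of chlorine from the entry of methoxy. A phenyl bearing an amine or a carboxylic acid is also untested among the compounds shown.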